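Ethynyl in place of 1-benzofuran-2-yl on an aromatic carbon

A few compounds are considered here, and "the series" means these few. Any claim that something is new, unique, unknown or untested is made for them only; others in the source may bear on it.

Values in a functional assay on A549 cells (Homo sapiens), read by MTT assay, with a stated time of 72 h (a higher number here means a weaker inhibitor, a lower number a stronger inhibitor), so far
- compound 1 `C#Cc1cn([C@@H]2O[C@H](CO)[C@@H](O)[C@H]2O)c2ncnc(SC)c12` gives 140 nM in this series
- compound 2 `CNc1ncnc2c1c(-c1ccco1)cn2[C@@H]1O[C@H](CO)[C@@H](O)[C@H]1O` gives 2570 nM in this series
- compound 3 `CNc1ncnc2c1c(-c1cc3ccccc3o1)cn2[C@@H]1O[C@H](CO)[C@@H](O)[C@H]1O` gives > 20000 nM as a limit, not a number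

Compound 3 has no number, only the limit of > 20000 nM in this assay, at which 1 of the 3 values shown sits, to place it. Compound 4 `C#Cc1cn([C@@H]2O[C@H](CO)[C@@H](O)[C@H]2O)c2ncnc(NC)c12` differs from it by ethynyl in place of 1-benzofuran-2-yl on an aromatic carbon in a single change: ethynyl in place of 1-benzofuran-2-yl on an aromatic carbon. Among the measured compounds shown here, one measured step bears on this, an at least 7.7-fold higher number from compound 2 to compound 3 (0.89 log units; beyond the scatter) on going to 1-benzofuran-2-yl, so leaving that group should lower the number. Compound 1 also carries ethynyl and gives 140 nM on a core with a different substituent. A large drop, beyond the scatter, is therefore expected in this assay for this change. The expected size is an at least 33-fold lower number from compound 3 to compound 4 (1.52 log units; beyond the scatter) on these grounds. The estimate for compound 4 is 600 nM within an expected range of 80 nM to 5000 nM in this series.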

Compound 4, half-maximal inhibitory concentration: > 20000 nM
Compound 4: a limit, no number; the forecaster's own chance of this, stated with the estimate: 3%; at least 33-fold (1.52 log units) between middle value and limit.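

In this assay ethynyl on this aromatic carbon gives no measurable potency with methylamino on the shared core: compound 4 stands at a limit of the assay (> 20000 nM). Ethynyl is thus no gain over furan-2-yl (step: an at least 7.7-fold higher number from compound 2 to compound 4 (0.89 log units; beyond the scatter)), and the potency of compound 1 depends on methylsulfanyl (step: an at least 140-fold higher number from compound 1 to compound 4 (2.15 log units; beyond the scatter)). The step between compound 3 and compound 4 cannot be read, as both are limits: the limit of > 20000 nM in this assay, at which 2 of the 4 values shown sit.

Open, on these data alone, is how ethynyl behaves with a plain amino group in place of methylamino, and how furan-2-yl behaves with methylsulfanyl.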